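The source may hold more compounds than are shown below. What is called first, only, known or untested is meant among the compounds shown, and "the series" means these compounds.

Three compounds built on the shared core of compound 1 `COc1ccc(N/C(CCNC2=CC(=O)c3ccccc3C2=O)=N\S(=O)(=O)c2ccc(C)cc2)cc1` have been run in a functional assay on DU-145 cells (Homo sapiens) for cytotoxicity, read by MTT assay, with a stated time of 48 h; a lower number here means a stronger inhibitor, a higher number a weaker inhibitor. Compound 1 gives 12000 nM. Compound 2 `Cc1ccc(S(=O)(=O)/N=C(/CCNC2=CC(=O)c3ccccc3C2=O)Nc2ccc(F)cc2)cc1` gives 12200 nM. Compound 3 `Cc1ccc(S(=O)(=O)/N=C(/CCNC2=CC(=O)c3ccccc3C2=O)Nc2ccccc2I)cc1` gives 11700 nM, the lowest of the three numbers, though the gaps a 1.0-fold lower number from compound 1 to compound 3 (0.01 log units; within the scatter) and a 1.0-fold lower number from compound 2 to compound 3 (0.02 log units; within the scatter) both sit within the scatter, as does a 1.0-fold higher number from compound 1 to compound 2 (0.01 log units; within the scatter).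

Compound 4 `Cc1ccc(S(=O)(=O)/N=C(/CCNC2=CC(=O)c3ccccc3C2=O)Nc2cccc(C(F)(F)F)c2)cc1` is not yet measured; it differs from compound 3 by 3-(trifluoromethyl)phenyl in place of 2-iodophenyl on an amine nitrogen. The measured steps that bear on this are the two earlier changes at the same amine nitrogen, a 1.0-fold lower number from compound 1 to compound 3 (0.01 log units; within the scatter) and a 1.0-fold lower number from compound 2 to compound 3 (0.02 log units; within the scatter), neither of which moved the number beyond the scatter, so no step beyond the scatter in this assay is expected here either. Compound 4 is therefore estimated at 12000 nM, with a range from 6000 nM to 24000 nM. The expected step of a 1.0-fold higher number from compound 3 to compound 4 (0.01 log units; within the scatter) is within the scatter.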

Compound 4, half-maximal inhibitory concentration: 84100 nM
The estimate for compound 4 lay 7.0-fold (0.85 log units) below the measured number; the measured number lies above the stated range.
By their numbers in this assay, from the lowest: compounds 3, 1 and 2 (each within the scatter of the next); then compound 4.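

In this assay the amine nitrogen now proves sensitive to its aryl group: a 7.2-fold higher number from compound 3 to compound 4 (0.86 log units; beyond the scatter) and a 6.9-fold higher number from compound 2 to compound 4 (0.84 log units; beyond the scatter) and a 7.0-fold higher number from compound 1 to compound 4 (0.85 log units; beyond the scatter) all lie beyond the scatter, whereas the steps among the three earlier groups stayed within it. Of the four groups shown, only 3-(trifluoromethyl)phenyl separates from the rest, and it does so towards weaker inhibition. No measurement available here accounts for this step.

The compounds shown do not separate the trifluoromethyl group from its place on the phenyl ring. As far as these compounds go, whether a nitrile or a carboxylic acid on that ring would also raise the number remains open.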